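This account rests on a few compounds, and the source may have more. Where it says the series, first, only, none or still open, it means among the compounds named here.

Compound 1 `O=C1CS/C(=N/Nc2nncc3ccccc23)N1c1ccccc1` gives 32 nM
Compound 2 `COc1ccc(NC(=S)NNc2nncc3ccccc23)cc1` gives 67 nM
Compound 3 `NS(=O)(=O)c1ccc(Nc2nncc3ccccc23)cc1` gives 23 nM

All three were tested in a functional assay on COLO 205 cells (Homo sapiens) for antiproliferative activity, read by sulforhodamine B assay, with a stated time of 72 h; on this read-out lower numbers stand for stronger inhibition and higher numbers for weaker inhibition. Compound 1 stands second highest of the three numbers; compound 3 lies within the scatter of it, while compound 2 shows a higher number, beyond the scatter. Compound 4 `O=C1CS/C(=N/Nc2nncc3ccccc23)N1` has not yet been measured. It differs from compound 1 in one place: hydrogen in place of phenyl on an amide-type nitrogen in a ring. Within the data shown here, no step between measured compounds follows this change, so the expectation rests on compound 1 alone. In this assay the loss of the phenyl is expected to give a modest step toward a higher number, beyond the scatter, a 3.1-fold higher number from compound 1 to compound 4 (0.49 log units; beyond the scatter). Compound 4 is therefore estimated at 100 nM, with a range from 30 nM to 400 nM.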

Compound 4, half-maximal inhibitory concentration: 55 nM
Compound 4: the middle estimate sits 1.8-fold (0.26 log units) above what was measured; low and high end bracket the measured number.
By their numbers in this assay, from the lowest: compounds 3, 1, 4 and 2 (each within the scatter of the next, the first and the last beyond it).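

Hydrogen in place of phenyl on the amide-type nitrogen in a ring gives a 1.7-fold higher number from compound 1 to compound 4 (0.24 log units; within the scatter) in this assay. The earlier compounds shown here carried no comparison at this position; this pair shows that, on this read-out, the two compounds cannot be told apart, so the phenyl is not required there. Nothing shown gives a reason for this result.

As far as these compounds go, whether a methyl, a benzyl or a longer chain on this nitrogen would read differently from hydrogen and phenyl stays open. So does the effect of a phenyl carrying a methoxy group or a sulfonamide there.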